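Lengthening the Amine Chain in a Clearance-Limited Series

The source may hold more compounds than are shown below. What is called first, only, known or untested is meant among the compounds shown, and "the series" means these compounds.

In an ADME assay on liver (strain Wistar) for metabolic stability, with Liver microsome (Rattus norvegicus) as the target, read by LC-MS, using microsomes and NADPH, with a stated time of 15 min, tested at 1 uM (a lower number here means slower removal, a higher number faster removal of the compound), compound 1 `CCc1cc(-c2noc(-c3cc(C)nc(CN(C)CC(C)C)c3)n2)cc(C)c1OC[C@@H](O)CNC(=O)CO` gives 197 mL.min-1.g-1. Compound 2 `CCc1cc(-c2noc(-c3cc(C)cc(CN(C)C)c3)n2)cc(C)c1OC[C@@H](O)CNC(=O)CO` returns only a limit of the assay, > 1250 mL.min-1.g-1. Compound 3 `CCc1cc(-c2noc(-c3cc(C)cc(CN(C)CC)c3)n2)cc(C)c1OC[C@@H](O)CNC(=O)CO` likewise sits at a limit, > 1250 mL.min-1.g-1. Because both of those values rest on (the limit of > 1250 mL.min-1.g-1 in this assay, at which 2 of the 3 values shown sit), the step that the two limits leave unreadable from compound 2 to compound 3. Compound 4 `CCCCN(C)Cc1cc(C)cc(-c2nc(-c3cc(C)c(OC[C@@H](O)CNC(=O)CO)c(CC)c3)no2)c1` differs from compound 3 by ethyl in place of hydrogen on a saturated chain carbon, two bonds along the chain from an amine nitrogen. Among the compounds with values here, no measured step bears directly on this change: the neighbouring step from compound 2 to compound 3 has no readable size, and compound 1 differs from compound 3 in more than one place, so its value cannot be tied to this chain alone. For compound 4 the estimate is therefore 1250 mL.min-1.g-1, within 600 mL.min-1.g-1 and 2500 mL.min-1.g-1, a step of a number no higher from compound 3 to compound 4 (the limit leaves the size open) expected to stay within the scatter and most likely again a limit.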

Compound 4, intrinsic clearance in microsomes: 183 mL.min-1.g-1
Compound 4: middle estimate off by 6.8-fold (0.83 log units), on the high side; the measured number lies below the stated range.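

In this assay, the amine chain at this position now gives its first readable change: butyl(methyl)amino in place of ethyl(methyl)amino gives an at least 6.8-fold lower number from compound 3 to compound 4 (0.83 log units; beyond the scatter), and the step of an at least 6.8-fold lower number from compound 2 to compound 4 (0.83 log units; beyond the scatter) runs the same way. Both steps show only a least size because compound 2 and compound 3 each rest on a limit: the limit of > 1250 mL.min-1.g-1 in this assay, at which 2 of the 4 values shown sit.

The compounds shown leave open whether a propyl chain on the same amine would already lower the number. They also leave open whether a chain longer than butyl would lower it further.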